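The source may report more compounds than this note shows. Statements on the series, on what has been measured and on what is new or still open speak of the compounds shown alone.

In an assay on isolated protein for inhibition of Rho-associated protein kinase 1 (Homo sapiens), read by mobility shift assay (on this read-out lower numbers stand for stronger inhibition and higher numbers for weaker inhibition), compound 1 `COc1cccc([C@@H](C)NC(=O)c2ccc(-c3cn[nH]c3)c(C)c2)c1` gives 8.7 nM, and compound 2 `CCc1cc(C(=O)N[C@H](C)c2cccc(OC)c2)ccc1-c1cn[nH]c1` gives 0.8 nM. Within the data shown here, compound 2 therefore stands lowest of the two numbers measured so far, with compound 1 as its only neighbour, and the only measured step, an 11-fold lower number from compound 1 to compound 2 (1.04 log units; beyond the scatter), arose from methyl in place of hydrogen on a saturated chain carbon bound to an aromatic carbon of the shared core.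

Compound 3 `COc1cccc([C@@H](C)NC(=O)c2ccc(-c3cn[nH]c3)c(C#N)c2)c1` has not yet been measured in this assay. It differs from compound 2 by cyano in place of ethyl on an aromatic carbon, ortho to a 1H-pyrazol-4-yl group and meta to a large group. Among the measured compounds shown here, no measured step bears on an exchange of this kind; the one step known, an 11-fold lower number from compound 1 to compound 2 (1.04 log units; beyond the scatter), shows only that the numbers at this position move by a large amount when the group there is altered. Because the change from ethyl to cyano is of a different kind from the measured step of an 11-fold lower number from compound 1 to compound 2 (1.04 log units; beyond the scatter), the expected step of a 13-fold higher number from compound 2 to compound 3 (1.10 log units; beyond the scatter) is given with wide bounds. Compound 3 is estimated at 10 nM, within a range from 2 nM to 60 nM.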

Compound 3, half-maximal inhibitory concentration: 56 nM
Compound 3: middle estimate off by 5.6-fold (0.75 log units), on the low side; the range from low to high includes it.
By their numbers in this assay, from the lowest: compound 2; then compound 1; then compound 3.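

In this assay, the exchange at this aromatic carbon, ortho to a 1H-pyrazol-4-yl group, now gives a 70-fold higher number from compound 2 to compound 3 (1.85 log units; beyond the scatter), a larger step than the one measured earlier. Ethyl and cyano both bring 2 heavy atoms, so the heavy-atom count of the group does not by itself set the number at this position. Cyano also compares unfavourably with the smaller carbon group, with a 6.4-fold higher number from compound 1 to compound 3 (0.81 log units; beyond the scatter), so the three compounds now place ethyl lowest, methyl in the middle and cyano highest, although nothing available accounts for this order.

The compounds shown leave open whether a longer chain such as propyl, or a branched one such as isopropyl, would extend the gain seen from methyl to ethyl, and whether a halogen such as chlorine would fall nearer the two carbon chains or nearer cyano. They also leave open whether this order of groups would persist if the rest of the shared core were changed, since all three compounds differ only at this one position.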